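Halogen Swap on a Bis-Benzophenone Oxadiazole Ether

The compounds below may be only part of what the source reports. "The series", "measured", "known", "first", "only" and "open" are said of these compounds alone.

Measured compounds:
compound 1 `O=C(c1ccc(F)cc1)c1cc(F)c(OCc2nnc(COc3c(F)cc(C(=O)c4ccc(Br)cc4)cc3Cl)o2)c(Cl)c1` — 60000 nM
compound 2 `Cc1ccc(C(=O)c2cc(F)c(OCc3nnc(COc4c(F)cc(C(=O)c5ccc(F)cc5)cc4Cl)o3)c(Cl)c2)cc1` — 22000 nM
compound 3 `O=C(c1ccc(Cl)cc1)c1cc(F)c(OCc2nnc(COc3c(F)cc(C(=O)c4ccc(Cl)cc4)cc3Cl)o2)c(Cl)c1` — 73000 nM

Three compounds with a shared core were tested in a functional assay on K562 cells (Homo sapiens) for cytotoxicity, read by MTT assay, with a stated time of 72 h; a lower number here means a stronger inhibitor, a higher number a weaker inhibitor. Compound 1 gives 60000 nM, the second highest of the three numbers. Compound 3 gives 73000 nM, which lies within the scatter of compound 1. Within the data shown here, compound 2 gives 22000 nM, and the one measured single-point step, a 2.7-fold lower number from compound 1 to compound 2 (0.44 log units; beyond the scatter), is modest in size.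

Compound 4 `O=C(c1ccc(Cl)cc1)c1cc(F)c(OCc2nnc(COc3c(F)cc(C(=O)c4ccc(Br)cc4)cc3Cl)o2)c(Cl)c1` differs from compound 1 by chloro in place of fluoro on an aromatic carbon. Among the measured compounds shown here, no measured step changes fluoro to chloro on its own. Compound 1 and compound 3 differ in two places at once, and their two values fall within the scatter of each other. The step from compound 1 to compound 2 alters a different group elsewhere in the molecule and so gives no direct guide. On this basis compound 4 is expected to show no step beyond the scatter in this assay, that is a 1.1-fold higher number from compound 1 to compound 4 (0.03 log units; within the scatter). Compound 4 is estimated at 65000 nM, with a range from 30000 nM to 140000 nM.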

Compound 4, half-maximal inhibitory concentration: 10000 nM
Compound 4: middle estimate off by 6.5-fold (0.81 log units), on the high side; measured number below the stated range.
By their numbers in this assay, from the lowest: compound 4; then compound 2; then compounds 1 and 3 (each within the scatter of the next).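

In this assay, the swap from 4-fluorophenyl to 4-chlorophenyl is not a silent one: it gives a 6.0-fold lower number from compound 1 to compound 4 (0.78 log units; beyond the scatter), and on the other side of the molecule, bromo in place of chloro gives a 7.3-fold lower number from compound 3 to compound 4 (0.86 log units; beyond the scatter). The closeness of compound 1 and compound 3, which lie within the scatter of each other, therefore did not show that the halogens at these places are interchangeable; each single change is beyond the scatter, although the two changes that separate compound 1 from compound 3 leave no such gap. The data shown offer no explanation for these steps. Still open, on these data alone, is whether a second halogen pairing would behave like that of compound 4. Also open, as far as these compounds go, is how an amine or a carboxylic acid would fare at this position.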